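The source may report more compounds than this note shows. Statements on the series, on what has been measured and on what is new or still open speak of the compounds shown alone.

Working notes on the series. Compound 3 `COc1cc(-c2nn(-c3cccc(NC(=O)Nc4cccc(C(F)(F)F)c4)c3)cc2-c2ccncc2)ccc1Cl` is the reference point here. Going by the values given here, in a functional assay on OVCAR-8 cells (Homo sapiens) for inhibition, read by sulforhodamine B assay, with a stated time of 48 h (on this read-out higher numbers stand for weaker inhibition of growth and lower numbers for stronger inhibition of growth), compound 3 gives 2700 nM, the lowest of the two numbers measured so far, though its nearest neighbour sits within the usual scatter. That neighbour is compound 2 `COc1cc(-c2nn(-c3cccc(NC(=O)Nc4cc(C(F)(F)F)cc(C(F)(F)F)c4)c3)cc2-c2ccncc2)ccc1Cl`, which in this assay gives 3980 nM. The step of a 1.5-fold lower number from compound 2 to compound 3 (0.17 log units; within the scatter) is therefore too small to count as a real difference. Compound 1 `O=C(Nc1cccc(-n2cc(-c3ccncc3)c(-c3ccc(Cl)c(O)c3)n2)c1)Nc1cccc(C(F)(F)F)c1` differs from compound 3 by bearing hydrogen rather than methyl on the ring oxygen. For compound 1 this assay reports only a limit, > 32500 nM. On that basis the step of an at least 12-fold lower number from compound 1 to compound 3 (1.08 log units; beyond the scatter) is large, and this is reflected in the limit of > 32500 nM in this assay, at which 1 of the 3 values shown sits.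

Compound 4 `COc1cc(-c2nn(-c3cccc(NC(=O)Nc4ccc(Cl)c(C(F)(F)F)c4)c3)cc2-c2ccncc2)ccc1Cl` is next. Relative to compound 3 the change is chloro in place of hydrogen on an aromatic carbon. Among the compounds with values here, the only measured step touching the same ring is the removal of a trifluoromethyl group, a 1.5-fold lower number from compound 2 to compound 3 (0.17 log units; within the scatter), which stayed within the scatter; no measured step adds a halogen to this ring. Adding a single chloro group in the position described is therefore expected to give no step beyond the scatter in this assay, with the expected step from compound 3 to compound 4 being a 1.2-fold lower number from compound 3 to compound 4 (0.09 log units; within the scatter). For compound 4 in this assay the estimate is 2200 nM, with a plausible range from 800 nM to 6000 nM.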

Compound 4, concentration for total growth inhibition: 5870 nM
For compound 4 the middle estimate is 2.7-fold (0.43 log units) below the measured one; the range from low to high includes it.
By their numbers in this assay, from the lowest: compounds 3, 2 and 4 (each within the scatter of the next, the first and the last beyond it). At a limit, above all of these: compound 1.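

In this assay, going by these compounds alone, the step of a 2.2-fold higher number from compound 3 to compound 4 (0.34 log units; beyond the scatter) is the first measured change on this ring to go beyond the scatter, while the step of a 1.5-fold lower number from compound 2 to compound 3 (0.17 log units; within the scatter) stayed within it. The position ortho to a trifluoromethyl group and para to a large group therefore responds to substitution, and here a single chloro group, one heavy atom, moves the number towards weaker inhibition of growth, though only modestly. Nothing available for this series bears on why this chloro group gives this step.

As far as these compounds go, whether the step belongs to chloro in particular or to any group at this position stays open: a fluoro, methoxy or amine group here would separate the two readings, and a carboxylic acid or a longer chain would show how far the position tolerates larger changes. Also open is whether the chloro group would give the same step on a ring without the trifluoromethyl group, since the 4-chloro-3-(trifluoromethyl)phenyl ring is the only chlorinated ring shown.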